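Polyamine chain series: from compound 2 to compound 4

The source may report more compounds than this note shows. Statements on the series, on what has been measured and on what is new or still open speak of the compounds shown alone.

Measured in a functional assay on L1210 cells (Mus musculus) for inhibition, with a stated time of 96 h; on this read-out lower numbers stand for stronger inhibition and higher numbers for weaker inhibition:
- Compound 1 `CCNCCCCNCCCN`: 40000 nM
- Compound 2 `CCCNCCCCNCCCN`: 55000 nM
- Compound 3 `CNCCCCNCCCCNC`: 900 nM

Compound 2, at 55000 nM, lies within the scatter of compound 1 and well above compound 3 in this assay. The next structure is compound 4 `CCCNCCCCNCCCCNCCC`, with the change (propylamino)methyl in place of amino on a saturated chain carbon, three bonds along the chain from an amine nitrogen.

Going by the values given here, the only measured step is a 1.4-fold higher number from compound 1 to compound 2 (0.14 log units; within the scatter). It concerns a different change and gives no sign of a shift beyond the scatter, so it bears on this one only weakly. Among the compounds with values here, the better guide is compound 3 at 900 nM, the only measured compound with matching alkyl groups at both chain ends, as in compound 4. A single compound cannot separate the effects of its differences from compound 4, so the uncertainty is wide.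

A clearly lower number is expected, with an estimated 22-fold lower number from compound 2 to compound 4 (1.34 log units; beyond the scatter). For compound 4 the estimated value is 2500 nM, with an expected range of 400 nM to 15000 nM.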

Compound 4, half-maximal inhibitory concentration: 6000 nM
The estimate for compound 4 lay 2.4-fold (0.38 log units) below the measured number; the measured number falls inside the stated range.
By their numbers in this assay, from the lowest: compound 3; then compound 4; then compounds 1 and 2 (each within the scatter of the next).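

In this assay, (propylamino)methyl in place of amino on a saturated chain carbon, three bonds along the chain from an amine nitrogen, gives a 9.2-fold lower number from compound 2 to compound 4 (0.96 log units; beyond the scatter) and so moves the number beyond the scatter. Going by these compounds alone, the only earlier step, a 1.4-fold higher number from compound 1 to compound 2 (0.14 log units; within the scatter), stayed within the scatter, which makes this position the first where a single change has a clear effect. The entering group brings 5 heavy atoms in place of 1, while the counts of hydrogen-bond donors and acceptors stay the same, and nothing available accounts for the step.

From the compounds shown here alone, the change adds both carbon and a further amine nitrogen with its propyl group, so the contribution of each part remains open. Going by these compounds, how (butylamino)methyl or a longer chain in the same place would read out in this assay also remains open.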